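From methoxy to cyclopropylamino on a shared core

A few compounds are considered here, and "the series" means these few. Any claim that something is new, unique, unknown or untested is made for them only; others in the source may bear on it.

In an ADME assay on CCRF-CEM cells (Homo sapiens) for cytotoxicity, read by MTT assay, with a stated time of 4 days (on this read-out higher numbers stand for lower toxicity in this test and lower numbers for higher toxicity in this test), compound 1 (`Nc1ncnc2c1ncn2[C@H]1CO[C@@H](CO)O1`) gives 28000 nM. Compound 2 (`COc1ncnc2c1ncn2[C@H]1CO[C@@H](CO)O1`) gives > 100000 nM, which is a limit of the assay and not a number. Its standing is therefore known only as the limit of > 100000 nM in this assay, at which 1 of the 2 values shown sits.

Compound 3 (`OC[C@@H]1OC[C@H](n2cnc3c(NC4CC4)ncnc32)O1`) differs from compound 2 by cyclopropylamino in place of methoxy on an aromatic carbon. In words, cyclopropylamino sits in place of methoxy on an aromatic carbon.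

Among the measured compounds shown here, only one measured step bears on this change: an at least 3.5-fold higher number from compound 1 to compound 2 (0.55 log units; beyond the scatter). That step is beyond the scatter, and it is methoxy in place of amino, close to the reverse of the new change. Read backwards, it suggests a lower number and so more toxicity in this assay, though no measured compound carries the cyclopropyl ring. The expected step is an at least 2.0-fold lower number from compound 2 to compound 3 (0.30 log units; that floor lies within the scatter). The estimated value for compound 3 is 50000 nM, with an expected range from 15000 nM to 120000 nM.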

Compound 3, half-maximal cytotoxic concentration: > 100000 nM
Compound 3: only a limit was reported; the forecaster's own chance of this, stated with the estimate: 40%; middle value at least 2.0-fold (0.30 log units) away from the limit.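

In this assay compound 3 gives > 100000 nM, which is a limit of the assay and not a number. Cyclopropyl in place of hydrogen on the nitrogen brings an at least 3.5-fold higher number from compound 1 to compound 3 (0.55 log units; beyond the scatter), so at this position a nitrogen attached to the core does not by itself give the higher toxicity of compound 1; the hydrogen on that nitrogen can be replaced with a loss of toxicity in this test. The step between compound 2 and compound 3 cannot be read, because both stand at the same limit: the limit of > 100000 nM in this assay, at which 2 of the 3 values shown sit.

From the compounds shown here alone, how far above that limit compound 2 and compound 3 lie remains open. So does whether the cyclopropyl ring matters as a ring, which a methyl group or a longer chain such as butyl on the same nitrogen could help to settle.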